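This account rests on a few compounds, and the source may have more. Where it says the series, first, only, none or still open, it means among the compounds named here.

Measured so far:
compound 1, `CCCc1nn(-c2nc(N)c3c(n2)NC(=O)C3(C)C)c2ccc(Cl)cc12` — 546000 nM
compound 2, `COC(=O)N(C)c1c(N)nc(-n2nc(Cc3c(F)ccc(F)c3F)c3cc(Cl)ccc32)nc1N` — 700 nM

In an assay on CHO cells for activation of soluble guanylate cyclase alpha1/beta1 complex (Homo sapiens), read by cGMP accumulation (a lower number here means that less compound is needed, a higher number that more compound is needed for the effect), compound 1 gives 546000 nM, the higher of the two numbers on hand. Compound 2 gives 700 nM in this assay, a gap beyond the scatter. Compound 2 and compound 1 differ in several places at once, so the two values show only that the series spans a wide range; they do not attach the gap to any single change.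

Compound 3, `CC1(C)C(=O)Nc2nc(-n3nc(CCC(F)(F)F)c4cc(Cl)ccc43)nc(N)c21`, is not yet measured. It differs from compound 1 in one place: trifluoromethyl in place of methyl on a saturated chain carbon, two bonds along the chain from an aromatic carbon. Among the measured compounds shown here, no measured pair shows this change, so its size has to be guessed. The expectation is a step from compound 1 to compound 3 of moderate size toward a lower number, a 3.6-fold lower number from compound 1 to compound 3 (0.56 log units; beyond the scatter), with a real chance that the step is no larger than the scatter. For compound 3 the estimate in this assay is 150000 nM, within 30000 nM to 600000 nM.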

Compound 3, half-maximal effective concentration: 87000 nM
Estimate against measurement, compound 3: 1.7-fold (0.24 log units) above, and the stated range covers the measured number.
By their numbers in this assay, from the lowest: compound 2; then compound 3; then compound 1.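

In this assay, among the compounds shown here, trifluoromethyl in place of methyl on a saturated chain carbon, two bonds along the chain from an aromatic carbon, gives the first single-place step, a 6.3-fold lower number from compound 1 to compound 3 (0.80 log units; beyond the scatter), modest in size but beyond the scatter. The earlier pair differed in several places and tied its gap to no single change, whereas this position now has one change with a direction attached, though a single pair sets no trend across the series. No measurement on hand bears on what lies behind this step.

Whether the step is particular to trifluoromethyl stays open, since this is the only replacement shown at the end of the propyl chain; a difluoromethyl group, a nitrile, a hydroxyl group or a carboxylic acid at the same place, or a longer chain, would show how much of it is specific to that group. Also open is whether the same change carries over to the core of compound 2, as no pair on that core is shown.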